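A few compounds are considered here, and "the series" means these few. Any claim that something is new, unique, unknown or untested is made for them only; others in the source may bear on it.

Measured compounds in a functional assay on HCC 2998 cells (Homo sapiens) for antiproliferative activity; a lower number here means a stronger inhibitor of growth, a higher number a weaker inhibitor of growth:

compound 1, `Oc1ccc(-c2nc3ccccc3s2)cc1O`: 6990 nM
compound 2, `Oc1ccc(-c2nc3cc(F)ccc3s2)cc1O`: 1640 nM
compound 3, `COc1ccc(-c2nc3cc(F)ccc3s2)cc1O`: 7600 nM

Compound 2 stands at the lowest number of the three in this assay; compound 1 is nearest, and compound 3 furthest, each beyond the scatter. The two measured steps are of similar size and opposite sense: a 4.3-fold lower number from compound 1 to compound 2 (0.63 log units; beyond the scatter), fluoro in place of hydrogen on an aromatic carbon, and a 4.6-fold higher number from compound 2 to compound 3 (0.67 log units; beyond the scatter), methyl in place of hydrogen on an oxygen on an aromatic ring.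

Compound 4, `COc1cc(-c2nc3cc(F)ccc3s2)ccc1O`, has not been measured. It differs from compound 2 by methyl in place of hydrogen on an oxygen on an aromatic ring; the same kind of change as from compound 2 to compound 3, but applied to the hydroxy group that compound 3 keeps free, so that compound 3 and compound 4 are methylated at different oxygens of the same shared core.

For the measured compounds named here, only one measured step bears on this change directly: compound 2 to compound 3, a modest step toward a higher number. Going by the values given here, no measured compound tells whether the two hydroxy groups behave alike, so the expectation for compound 4 is taken from that single step, with a wider range to cover the difference in oxygen. A step of roughly the same size and direction is expected: a 3.7-fold higher number from compound 2 to compound 4 (0.56 log units; beyond the scatter). Compound 4 is therefore estimated at 6000 nM in this assay, within 2500 nM to 15000 nM.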

Compound 4, concentration for 50% growth inhibition: 1040 nM
Compound 4: middle estimate off by 5.8-fold (0.76 log units), on the high side; measured number below the stated range.
By their numbers in this assay, from the lowest: compounds 4 and 2 (each within the scatter of the next); then compounds 1 and 3 (each within the scatter of the next).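

Methyl in place of hydrogen on an oxygen on an aromatic ring does not give one outcome across the two hydroxy groups of compound 2: in this assay the step at this oxygen reads a 1.6-fold lower number from compound 2 to compound 4 (0.20 log units; within the scatter), whereas the step at the other oxygen reads a 4.6-fold higher number from compound 2 to compound 3 (0.67 log units; beyond the scatter). For the compounds shown here, this oxygen therefore takes the hydroxy to methoxy change with no shift beyond the scatter, so a free hydroxy group here is not required for the number seen with compound 2, and the single earlier step does not transfer from one oxygen to the other. Nothing shown accounts for the difference between the two oxygens.

The compounds shown leave open whether this oxygen also accepts something larger than methyl, such as an ethyl group or a longer chain, or whether an amine can stand in place of the hydroxy group. They also leave open what happens with methyl on both oxygens, and whether the fluoro group keeps its effect in the methoxy series, since compound 4 has no partner without fluoro.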